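A few compounds are considered here, and "the series" means these few. Any claim that something is new, unique, unknown or untested is made for them only; others in the source may bear on it.

Values in a toxicity assay on MDCK cells (Canis lupus familiaris) for cytotoxicity, read by CCK-8 assay, with a stated time of 48 h; a higher number here means that more compound is tolerated, a lower number that less compound is tolerated
compound 1 `COc1ccc(C(=O)NNc2c(Br)cccc2Br)cc1` gives > 100000 nM (a limit)
compound 2 `CCc1ccc(C(=O)NNc2c(Br)cccc2Br)cc1` gives > 100000 nM (a limit)
compound 3 `COC(=O)c1ccc(C(=O)NNc2c(Br)cccc2Br)cc1` gives 87600 nM

For the measured compounds named here, compound 3 carries the only number. Compound 1 and compound 2 both stand at the limit of > 100000 nM in this assay, at which 2 of the 3 values shown sit, and give no number.

The next change leads to compound 4 `O=C(NNc1c(Br)cccc1Br)c1ccccc1` with hydrogen in place of methoxycarbonyl on an aromatic carbon as the whole difference. Going by the values given here, two measured steps bear on this place: an at least 1.1-fold lower number from compound 1 to compound 3 (0.05 log units; that floor lies within the scatter) and also an at least 1.1-fold lower number from compound 2 to compound 3 (0.05 log units; that floor lies within the scatter) in the same direction. Both bring methoxycarbonyl in, and neither has hydrogen at that carbon, so the size of this change is not measured directly. On the small floors of those two steps to compound 3, no step beyond the scatter is expected in this assay and, if anything, a slightly higher number. A reading that returns only a limit is quite possible. The step expected is a 1.1-fold higher number from compound 3 to compound 4 (0.06 log units; within the scatter) by this estimate. Compound 4 is estimated at 100000 nM with an expected range from 50000 nM to 200000 nM in this series.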

Compound 4, half-maximal cytotoxic concentration: > 100000 nM
Compound 4 ended at the assay's limit; the forecaster's own chance of this, stated with the estimate: 60%; the middle value sits exactly at the limit.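

In this assay compound 4 gives > 100000 nM, which is a limit and not a number. For the compounds shown here, with hydrogen in place of methoxycarbonyl on this aromatic carbon, para to a large group, the result is an at least 1.1-fold higher number from compound 3 to compound 4 (0.05 log units; that floor lies within the scatter), so the parent without any group here shows no step beyond the scatter from the one compound that carries a number. The steps to compound 4 from compound 1 and from compound 2 cannot be read, and hydrogen, methoxy and ethyl at this carbon remain undistinguished: the limit of > 100000 nM in this assay, at which 3 of the 4 values shown sit.

As far as these compounds go, whether methoxycarbonyl truly lowers the tolerated concentration remains open, with every readable step at this carbon still resting on a floor within the scatter. Also open, from the compounds shown here alone, is what a carboxylic acid, an amine or a longer chain at this carbon would give in this assay.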